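Replacing the 4-phenylphenyl group on the ring nitrogen

This account rests on a few compounds, and the source may have more. Where it says the series, first, only, none or still open, it means among the compounds named here.

Compound 3 `O=C(NCCCCc1ccccc1)c1cccc(C2SCC(=O)N2c2ccc(-c3ccccc3)cc2)c1` carries a 4-phenylphenyl group on the amide-type nitrogen in the ring of the shared core. In a functional assay on HOS-TE85 cells (Homo sapiens) for inhibition, read by CCK-8 assay, with a stated time of 72 h (on this read-out lower numbers stand for stronger inhibition and higher numbers for weaker inhibition), compound 3 gives > 1000 nM, which is a limit of the assay and not a number. Compound 1 `O=C(NCCCCc1ccccc1)c1cccc(C2SCC(=O)N2c2cccc(-c3c[nH]nn3)c2)c1` differs from compound 3 only in that group. In this assay compound 1 gives 110 nM. Among the compounds with values here, the step of an at least 9.0-fold higher number from compound 1 to compound 3 (0.95 log units; beyond the scatter) is the one measured comparison that bears on this position, and its size is known only as a bound because compound 3 sits at the limit of > 1000 nM in this assay, at which 1 of the 3 values shown sits. Compound 2 `COc1ccc(F)cc1N1C(=O)CSC1c1cccc(C(=O)NCCCCn2cccn2)c1`, which bears a different tail on the amide and a substituted single phenyl ring on the ring nitrogen, gives 97.3 nM in this assay.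

Compound 4 `COc1ccc(C)cc1N1C(=O)CSC1c1cccc(C(=O)NCCCCc2ccccc2)c1` returns to a single substituted phenyl ring at this position: 2-methoxy-5-methylphenyl in place of 4-phenylphenyl on an amide-type nitrogen in a ring. Compound 1 shows that a smaller group on the ring nitrogen sits well within the measured range, and compound 2 shows that a 2-methoxy-substituted phenyl on that nitrogen is compatible with a value near that of compound 1. Compound 4 is therefore expected to give 150 nM in this assay, with a range from 50 nM to 600 nM. The expected step of an at least 6.6-fold lower number from compound 3 to compound 4 (0.82 log units; beyond the scatter) is a clear move back below the limit.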

Compound 4, half-maximal inhibitory concentration: 300 nM
Compound 4: middle estimate off by 2.0-fold (0.30 log units), on the low side; measured number inside the range.
By their numbers in this assay, from the lowest: compounds 2 and 1 (each within the scatter of the next); then compound 4. At a limit, above all of these: compound 3.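

In this assay, 2-methoxy-5-methylphenyl in place of 4-phenylphenyl on the amide-type nitrogen in the ring gives an at least 3.3-fold lower number from compound 3 to compound 4 (0.52 log units; beyond the scatter), which shows that, with the amide tail held constant, this position does not need a second ring to give a measurable value. That step is known only as a bound, since the value of compound 3 is a limit of the assay and not a number: the limit of > 1000 nM in this assay, at which 1 of the 4 values shown sits.

The same position also separates the two measured compounds with this tail, with a 2.7-fold higher number from compound 1 to compound 4 (0.44 log units; beyond the scatter), so the group with the five-membered aromatic ring with 3 hetero atoms stays ahead of the single substituted phenyl ring, though only modestly compared with the step to the limit.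

On these data alone, it remains open whether an unsubstituted phenyl group, or a ring carrying only the methoxy or only the methyl, would hold the value of compound 4, and compound 2 cannot settle this, as it also differs in the amide tail. As far as these compounds go, it is equally open whether a carboxylic acid or an amine in place of the five-membered aromatic ring of compound 1 would keep that compound's value.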